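From 2,4-dichlorophenyl to 2,4-difluorophenyl

This account rests on a few compounds, and the source may have more. Where it says the series, first, only, none or still open, it means among the compounds named here.

In a functional assay on NCI/ADR-RES cells (Homo sapiens) for inhibition (on this read-out higher numbers stand for weaker inhibition of growth and lower numbers for stronger inhibition of growth), compound 3 `O=S(=O)(/C=C/c1ccc(Cl)cc1Cl)Cc1ccc(Nc2ncnc3ccccc23)cc1` gives 5000 nM and holds the lowest number of the set. Compound 1 `O=S(=O)(/C=C/c1ccc(Cl)c(Cl)c1)Cc1ccc(Nc2ncnc3ccccc23)cc1` gives 22000 nM in this assay as well. Compound 2 `O=S(=O)(/C=C/c1ccc(Br)cc1)Cc1ccc(Nc2ncnc3ccccc23)cc1` stands at > 100000 nM and this is a limit of the assay.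

Compound 4 `O=S(=O)(/C=C/c1ccc(F)cc1F)Cc1ccc(Nc2ncnc3ccccc23)cc1` differs from compound 3 by a single change, with 2,4-difluorophenyl in place of 2,4-dichlorophenyl on a double-bonded chain carbon bound to a double-bonded chain carbon. Two measured steps arrive at compound 3 through this same place: a modest one (a 4.4-fold lower number from compound 1 to compound 3 (0.64 log units; beyond the scatter)) and a large one (an at least 20-fold lower number from compound 2 to compound 3 (1.30 log units; beyond the scatter)). Both lie beyond the scatter, so the number responds clearly to changes here, although neither step swaps chlorine for fluorine.

Since compound 3 already sits lowest, a move to a higher number is expected, of about the modest size seen for compound 1 (a 4.4-fold lower number from compound 1 to compound 3 (0.64 log units; beyond the scatter)). The expected step is a 4.0-fold higher number from compound 3 to compound 4 (0.60 log units; beyond the scatter) in this assay and would mean weaker inhibition of growth. Compound 4 is estimated at 20000 nM with an expected range from 6000 nM to 80000 nM and no narrower claim is made.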

Compound 4, concentration for 50% growth inhibition: > 100000 nM
Compound 4 was reported as a limit; the forecaster's own chance of this, stated with the estimate: 15%; middle value at least 5.0-fold (0.69 log units) away from the limit.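

In this assay compound 4 gives > 100000 nM, which is a limit of the assay. The change from 2,4-dichlorophenyl to 2,4-difluorophenyl gives an at least 20-fold higher number from compound 3 to compound 4 (1.30 log units; beyond the scatter), and the change from 3,4-dichlorophenyl to 2,4-difluorophenyl gives an at least 4.5-fold higher number from compound 1 to compound 4 (0.65 log units; beyond the scatter), so among these compounds a low number goes with 2,4-dichlorophenyl and not with 2,4-difluorophenyl, and the identity of the halogen also counts. The step between compound 2 and compound 4 cannot be read, because both values are limits: the limit of > 100000 nM in this assay, at which 2 of the 4 values shown sit.

Going by these compounds, how far compound 4 lies beyond its limit stays open, so the full size of its steps is unknown. Also open, on these data alone, is whether 2,4-dibromophenyl or 2,4-dimethylphenyl at this place would give a number lower than that of compound 3.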